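Hydroxy for methyl: a step from compound 3

This account rests on a few compounds, and the source may have more. Where it says the series, first, only, none or still open, it means among the compounds named here.

Three compounds of this series have been run in a functional assay on the whole organism for inhibition, with Rattus norvegicus as the target, in the maximal electroshock model, at a dose of 25 mg/kg by the intraperitoneal route; a lower number here means less inhibition, a higher number more inhibition at the dose given (going by the name of the read-out). Compound 1 `C[C@@H](c1ccccc1)n1cnc2c(N(C)C)ncnc21` gives 33%. Compound 2 `Oc1ncnc2c1ncn2Cc1ccccc1` gives 17%. Compound 3 `Cc1ccc(Cn2cnc3c(N(C)C)ncnc32)cc1` gives 0%, the lowest of the three numbers; its nearest neighbour is compound 2, whose number is higher by a margin beyond the scatter, and the furthest is compound 1, higher still by a margin beyond the scatter. Within the data shown here, no two of the measured compounds differ in only one place, so no single step between them can be read off.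

Compound 4 `CN(C)c1ncnc2c1ncn2Cc1ccc(O)cc1` has not yet been measured in this assay. It differs from compound 3 in one place: hydroxy in place of methyl on an aromatic carbon. Among the measured compounds shown here, nothing among the measured compounds isolates the effect of this change. Given that compound 3 sits at 0%, the step of a number 10 percentage points higher from compound 3 to compound 4 (within the scatter) is expected to be small and upward, if anything, and may not clear the scatter. For compound 4 the inhibition in this assay is expected to come out near 10%, with a range from 0% to 35%.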

Compound 4, a percentage reported as inhibition, in the whole organism at one dose (the size of the read-out at that dose, not a potency): 0%
Estimate against measurement, compound 4: 10 percentage points above, and the stated range covers the measured number.
By their numbers in this assay, from the lowest: compounds 3 and 4 (each within the scatter of the next); then compound 2; then compound 1.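

In this assay, among these compounds, hydroxy in place of methyl on an aromatic carbon, para to a large group, gives no change at the digits printed from compound 3 to compound 4 (within the scatter) and provides the first single-place comparison. Compound 3 at 0% and compound 4 at 0% both print the same number, so swapping methyl for hydroxy at this position, which brings in a hydrogen-bond donor and acceptor, does not separate the two compounds at this dose. No measurement shown here offers an explanation for this result.

From the compounds shown here alone, whether an amine, a carboxylic acid or a longer chain at this position would give a different number remains open. Steps involving compound 1 or compound 2 cannot be read, as each differs from the other compounds in more than one place.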